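Swapping a phenyl for furan-2-yl on the shared core

This account rests on a few compounds, and the source may have more. Where it says the series, first, only, none or still open, it means among the compounds named here.

- compound 1 `Oc1cccc(-c2cc(-c3ccccc3)cc(-c3ccccc3)n2)c1` gives 18000 nM
- compound 2 `Oc1ccc(-c2cc(-c3ccccc3)cc(-c3ccccc3)n2)cc1` gives 3000 nM

Both values come from a functional assay on DU-145 cells (Homo sapiens) for cytotoxicity, read by ELISA, with a stated time of 2 days; on this read-out lower numbers stand for stronger inhibition and higher numbers for weaker inhibition. Of the two numbers, compound 2 has the lower, so it is the stronger inhibitor measured so far. Among the compounds with values here, the only measured step, a 6.0-fold lower number from compound 1 to compound 2 (0.78 log units; beyond the scatter), is 4-hydroxyphenyl in place of 3-hydroxyphenyl on an aromatic carbon.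

Compound 3 `Oc1ccc(-c2cc(-c3ccccc3)cc(-c3ccco3)n2)cc1` keeps the 4-hydroxyphenyl group of compound 2 and has furan-2-yl in place of phenyl on an aromatic carbon, next to the ring nitrogen: furan-2-yl in place of phenyl on an aromatic carbon. The measured step concerns a different group, so it bears on this change only loosely. It shows how far one small change can move the number in this set, but it gives no direction here. Within the data shown here, no measured compound carries furan-2-yl, so the data offer no direction of their own.

The expected step, a 1.2-fold higher number from compound 2 to compound 3 (0.07 log units; within the scatter), is therefore none beyond the scatter, although a shift as large as the measured one remains possible either way. In this assay, compound 3 is estimated at 3500 nM, with an expected range of 1200 nM to 11000 nM.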

Compound 3, half-maximal inhibitory concentration: 3200 nM
Compound 3: the middle estimate sits 1.1-fold (0.04 log units) above what was measured; the range from low to high includes it.
By their numbers in this assay, from the lowest: compounds 2 and 3 (each within the scatter of the next); then compound 1.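

At the aromatic carbon next to the ring nitrogen, phenyl can give way to furan-2-yl without a shift beyond the scatter in this assay: a 1.1-fold higher number from compound 2 to compound 3 (0.03 log units; within the scatter). Within the data shown here, this is the first sign that this position accepts a smaller ring holding an oxygen atom and a hydrogen-bond acceptor, at least in this one pair, whereas moving the hydroxyl group gave a step beyond the scatter, a 6.0-fold lower number from compound 1 to compound 2 (0.78 log units; beyond the scatter). Nothing available explains why the swap leaves the number within the scatter.

Going by these compounds, one pair cannot show how much freedom this position really has, so it remains open whether an amine, a carboxylic acid, a thiophene ring or a longer alkyl chain on the same carbon would leave the number within the scatter or move it clearly in either direction. On these data alone, it is also open whether furan-2-yl would behave the same way alongside the 3-hydroxyphenyl group of compound 1, or whether the same swap at the other phenyl group of the shared core would give a similar result.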